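The compounds below may be only part of what the source reports. "The series", "measured", "known", "first", "only" and "open" are said of these compounds alone.

Compound 2 `Cn1cnc(S(=O)(=O)N2C[C@@H]3[C@H](C2)[C@@]3(CNC(=O)c2cc(Cl)cc(Cl)c2)CC2CC2)c1` gives 100 nM in an assay on isolated protein for inhibition of sodium- and chloride-dependent glycine transporter 1 (Homo sapiens) (on this read-out lower numbers stand for stronger inhibition and higher numbers for weaker inhibition), the highest of the two numbers in hand; compound 1 `Cn1cnc(S(=O)(=O)N2C[C@@H]3[C@H](C2)[C@@]3(CNC(=O)c2ccc(Cl)cc2Cl)CC2CC2)c1` gives 4 nM. Among the compounds with values here, the only measured step, a 25-fold higher number from compound 1 to compound 2 (1.40 log units; beyond the scatter), came with a change of the aryl group on the carbonyl carbon. Compound 3 `Cn1cnc(S(=O)(=O)N2C[C@@H]3[C@H](C2)[C@@]3(CNC(=O)c2ccccc2C(F)(F)F)CC2CC2)c1` carries the change (2-(trifluoromethyl)phenyl in place of 3,5-dichlorophenyl on a carbonyl carbon). Within the data shown here, no measured step covers exactly this swap, but the large shift seen from compound 1 to compound 2 suggests the aryl group matters, so compound 3 is expected to show a lower number, estimated as a 6.7-fold lower number from compound 2 to compound 3 (0.82 log units; beyond the scatter). Compound 3 is therefore estimated at 15 nM, within 4 nM to 60 nM.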

Compound 3, half-maximal inhibitory concentration: 5 nM
For compound 3 the middle estimate is 3.0-fold (0.48 log units) above the measured one; low and high end bracket the measured number.
By their numbers in this assay, from the lowest: compounds 1 and 3 (each within the scatter of the next); then compound 2.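

In this assay the aryl group on the carbonyl carbon again counts heavily: a 20-fold lower number from compound 2 to compound 3 (1.30 log units; beyond the scatter) shows that the high number of compound 2 is not common to every substituted phenyl at this place. Set against 2,4-dichlorophenyl, 2-(trifluoromethyl)phenyl gives a 1.3-fold higher number from compound 1 to compound 3 (0.10 log units; within the scatter) and so no difference can be read between these two groups. Nothing given here explains why 3,5-dichlorophenyl stands apart from them. Going by these compounds, whether a pyridine ring or a cyclohexyl group on the carbonyl carbon would hold the low numbers of compound 1 and compound 3 remains open.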